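Replacing an Inactive Side Chain with an Aromatic Ring

This account rests on a few compounds, and the source may have more. Where it says the series, first, only, none or still open, it means among the compounds named here.

Compound 1, `CC(C(=O)NCc1ccc(C(F)(F)F)cc1N1CCCCCCC1)c1ccc(NS(C)(=O)=O)c(F)c1`: 2.8 nM
Compound 2, `CC(C(=O)NCc1ccc(C(F)(F)F)cc1N1CCC(C)(C)CC1)c1ccc(NS(C)(=O)=O)c(F)c1`: 1.3 nM
Compound 3, `CC(C(=O)NCc1ccc(C(F)(F)F)cc1SCCCO)c1ccc(NS(C)(=O)=O)c(F)c1`: "not active" (no number reported)

Of the compounds shown here, three on a shared core have been tested in an assay on CHO cells for antagonist activity at transient receptor potential cation channel subfamily V member 1 (Homo sapiens), read by FLIPR; a higher number here means a weaker inhibitor, a lower number a stronger inhibitor. Going by the values given here, compound 1 gives 2.8 nM and compound 2 gives 1.3 nM; the one measured step, a 2.2-fold lower number from compound 1 to compound 2 (0.33 log units; beyond the scatter), swaps one ring for another at the same aromatic carbon. Compound 3 stands apart: in this assay compound 3 is reported as "not active" (no number reported), with no number attached, so it cannot be placed on the scale of the other two.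

Compound 4, `CC(C(=O)NCc1ccc(C(F)(F)F)cc1-c1ccc(C(C)(C)C)cc1)c1ccc(NS(C)(=O)=O)c(F)c1`, differs from compound 3 in one place: 4-(tert-butyl)phenyl in place of (3-hydroxypropyl)sulfanyl on an aromatic carbon. Among the compounds with values here, no measured step covers a change from a chain to a ring, so the step from compound 3 to compound 4 has no direct precedent. What the numbers do show is that the two compounds carrying a ring at this aromatic carbon, compound 1 and compound 2, both return numbers, while compound 3 with the chain returns none. Compound 4 is therefore expected to give a number again, estimated near 6 nM, within a range of 1.5 nM to 40 nM.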

Compound 4, inhibition constant: 1.1 nM
For compound 4 the middle estimate is 5.5-fold (0.74 log units) above the measured one; measured number outside the range, below it.
By their numbers in this assay, from the lowest: compounds 4 and 2 (each within the scatter of the next); then compound 1.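

In this assay a group of carbon only, 4-(tert-butyl)phenyl, serves at this aromatic carbon as well as 4,4-dimethylpiperidin-1-yl does, with a 1.2-fold lower number from compound 2 to compound 4 (0.07 log units; within the scatter) as the step, so among these compounds a low number does not require a nitrogen attached there. Set against the eight-membered ring, the same group shows a 2.5-fold lower number from compound 1 to compound 4 (0.41 log units; beyond the scatter) as a modest step. No measurement shown bears on why these groups behave as they do.

Going by these compounds alone, compound 3 has no number, so no step from it can be read, and it remains open whether its result goes with the sulfur, the hydroxyl or the chain itself. From the compounds shown here alone, whether a pyridine ring, or a phenyl carrying a carboxylic acid or an amine in place of the tert-butyl, would hold the number in this assay is also open.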